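This account rests on a few compounds, and the source may have more. Where it says the series, first, only, none or still open, it means among the compounds named here.

Measured so far in a physicochemical assay for solubility, measured as kinetic solubility, with a stated time of 1 h, at pH 7.4; a higher number here means a more soluble compound, a lower number a less soluble compound
- Compound 1 `CC(=O)Nc1nc(-c2nc(C)no2)cs1` gives 186000 nM
- Compound 2 `N#CCC(=O)Nc1csc(-c2ccc(Cl)c(Cl)c2)n1` gives 2000 nM
- Compound 3 `CC(=O)NC1=NN(c2ccc(Cl)c(Cl)c2)CC1C` gives 49000 nM

Compound 3, at 49000 nM, stands second highest of the three, under compound 1 and over compound 2, and both gaps lie beyond the scatter. The next compound, compound 4 `CC(=O)NC1=NN(c2ccc(Cl)c(Cl)c2)C[C@@H]1C`, differs from it in one respect only: the two compounds have the same atoms and bonds; at least one stereo element is drawn with a configuration in one of them and without one in the other: 1 of 1 stereo elements differ; a stereocentre at a saturated ring carbon is drawn without a configuration in compound 3 and S in compound 4. Among the measured compounds shown here, no measured pair of compounds shows a step of this kind, so the expectation rests on the shared atoms and bonds alone. No step beyond the scatter is expected in this assay, and neither direction is favoured. The estimated change is small, a 1.0-fold higher number from compound 3 to compound 4 (0.01 log units; within the scatter). For compound 4 the expected value is 50000 nM, with an estimated range from 25000 nM to 100000 nM.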

Compound 4, solubility: 32000 nM
Compound 4: middle estimate off by 1.6-fold (0.19 log units), on the high side, and the stated range covers the measured number.
By their numbers in this assay, from the lowest: compound 2; then compounds 4 and 3 (each within the scatter of the next); then compound 1.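

Among the compounds shown here, compounds 3 and 4 form the first pair in this assay that differs in one place only, and the step is a 1.5-fold lower number from compound 3 to compound 4 (0.19 log units; within the scatter). Drawing the stereocentre at the saturated ring carbon as S rather than without a configuration therefore leaves the two numbers within the usual scatter of each other. For the compounds shown here, the only difference between the pair is this: the fact that one of compounds 3 and 4 is drawn with a defined configuration and the other without, at the place where they differ.

The compounds shown leave open what the R configuration at this carbon would give. They also leave open how an amine or a carboxylic acid on the shared core would read in this assay.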